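The source may report more compounds than this note shows. Statements on the series, on what has been measured and on what is new or still open speak of the compounds shown alone.

Compound 1 `Cc1ccccc1-c1nnc(NN)s1` is the parent of the series. In a functional assay on the whole organism with Mus musculus as the target, in the maximal electroshock model, with a stated time of 1 h (a lower number here means that less compound is needed, a higher number that more compound is needed for the effect), compound 1 reaches only a limit of the assay, > 100 mg/kg. Compound 2 `Cc1ccccc1-c1nnc(N(C)N)s1` differs by methyl in place of hydrogen on a nitrogen on an aromatic ring, and in this assay compound 2 gives 75 mg/kg, a step of an at least 1.3-fold lower number from compound 1 to compound 2 (0.12 log units; that floor lies within the scatter). Compound 3 `Cc1ccccc1-c1nnc(NNC(c2ccccc2)c2ccccc2)s1` is measured in this assay only as a limit, > 200 mg/kg. How the core of compound 3 differs from the core of compound 1 is not broken down here. Compound 4 `Cc1ccccc1-c1nnc(N(C)NC(c2ccccc2)c2ccccc2)s1` differs from compound 3 by methyl in place of hydrogen on a nitrogen on an aromatic ring, the same change as the earlier one. Given that compound 3 stands at a limit, the step expected for compound 4 is an at least 1.1-fold lower number from compound 3 to compound 4 (0.04 log units; that floor lies within the scatter), set beside the measured one and resting on an at least 1.3-fold lower number from compound 1 to compound 2 (0.12 log units; that floor lies within the scatter), whose floor lies within the scatter. Compound 4 is expected in this assay at about 180 mg/kg, between 60 mg/kg and 400 mg/kg, with a fair chance of again only a limit.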

Compound 4, dose for half-maximal effect: > 200 mg/kg
Compound 4: a limit, no number; the forecaster's own chance of this, stated with the estimate: 60%; at least 1.1-fold (0.04 log units) between middle value and limit.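

Compound 3 and compound 4 both sit at a limit in this assay, so no step can be read between them: the limit of > 200 mg/kg in this assay, at which 2 of the 4 values shown sit.

On these data alone, whether methyl in place of hydrogen on the nitrogen changes the dose needed in this pair remains open.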